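Swapping trifluoromethyl for fluoro at the assay's limit

The source may hold more compounds than are shown below. What is called first, only, known or untested is meant among the compounds shown, and "the series" means these compounds.

In a functional assay on ACHN cells (Homo sapiens) (a lower number here means a stronger inhibitor of growth, a higher number a weaker inhibitor of growth), compound 1 `O=S(=O)(/C=C/c1ccc(C(F)(F)F)cc1F)Cc1ccc(Nc2ncnc3ccccc23)cc1` gives 100000 nM, and compound 2 `O=S(=O)(/C=C/c1ccc(C(F)(F)F)cc1F)Cc1ccc(Nc2ncnc3ccc(Br)cc23)cc1` gives 16000 nM. Compound 3 `O=S(=O)(/C=C/c1ccc(C(F)(F)F)cc1F)Cc1ccc(Nc2ncnc3cc(Cl)ccc23)cc1` gives > 100000 nM, which is a limit of the assay and not a number.

Compound 4 `O=S(=O)(/C=C/c1ccc(F)cc1F)Cc1ccc(Nc2ncnc3cc(Cl)ccc23)cc1` keeps the core of compound 3 and changes the other end of the molecule: fluoro in place of trifluoromethyl on an aromatic carbon. This takes 2-fluoro-4-(trifluoromethyl)phenyl to 2,4-difluorophenyl.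

Going by the values given here, no measured step touches that group. All three change a halogen on the core: a 6.3-fold lower number from compound 1 to compound 2 (0.80 log units; beyond the scatter), a number no lower from compound 1 to compound 3 (the limit leaves the size open) and an at least 6.2-fold higher number from compound 2 to compound 3 (0.79 log units; beyond the scatter). They therefore bear on this change only indirectly, and they give no direction for it. Among the compounds with values here, the one step with a readable size, a 6.3-fold lower number from compound 1 to compound 2 (0.80 log units; beyond the scatter), serves as a rough guide, so a modest step at most is expected in this assay, and only a move to a lower number could be read as a value.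

The estimated change is an at least 1.6-fold lower number from compound 3 to compound 4 (0.22 log units; that floor lies within the scatter). For compound 4 the expected value is 60000 nM, within an expected range of 15000 nM to 100000 nM.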

Compound 4, concentration for 50% growth inhibition: > 100000 nM
Compound 4: no number, only a limit (the forecaster's own chance of this, stated with the estimate: 50%); middle value at least 1.6-fold (0.22 log units) away from the limit.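

The step from compound 3 to compound 4 cannot be read, because both values are limits of the assay and not numbers: the limit of > 100000 nM in this assay, at which 2 of the 4 values shown sit.

The compounds shown leave open whether fluoro in place of trifluoromethyl changes growth inhibition at all, and in which direction.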